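Swapping the aryl ring of a hydrazone kinase-type series

A few compounds are considered here, and "the series" means these few. Any claim that something is new, unique, unknown or untested is made for them only; others in the source may bear on it.

Measured compounds:
- Compound 1 `C=CC(=O)Nc1cccc(Nc2nc(N/N=C/c3ccccc3F)ncc2Cl)c1`: in an ADME assay on HT-29 cells (Homo sapiens) for inhibition, read by MTT assay, with a stated time of 72 h (on this read-out higher numbers stand for weaker inhibition and lower numbers for stronger inhibition), compound 1 gives 3500 nM
- Compound 2 `C=CC(=O)Nc1cccc(Nc2nc(N/N=C/c3ccc(F)cc3F)ncc2Cl)c1`: in this assay compound 2 gives 4760 nM
- Compound 3 `CN(C)C/C=C/C(=O)Nc1cccc(Nc2nc(N/N=C/c3ccc(F)cc3F)ncc2Cl)c1`: in this assay compound 3 gives 2920 nM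

Three compounds share one core and were run in this assay. Compound 3 has the lowest of the three numbers, but its neighbours sit close: compound 1 is only a 1.4-fold higher number from compound 1 to compound 2 (0.13 log units; within the scatter) apart from compound 2, and the step of a 1.6-fold lower number from compound 2 to compound 3 (0.21 log units; within the scatter) is likewise within the scatter. So far, then, the three compounds cannot be told apart on these numbers.

Compound 4 `C/C(=N\Nc1ncc(Cl)c(Nc2cccc(NC(=O)/C=C/CN(C)C)c2)n1)c1cccnc1` is the next candidate. Relative to compound 3 the change is a group of 9 heavy atoms (7 carbon, 2 nitrogen; one six-membered aromatic ring with 1 hetero atom) in place of a group of 10 heavy atoms (7 carbon, 1 nitrogen, 2 fluorine; one six-membered aromatic ring of carbon only), on a nitrogen on an aromatic ring. The ring that leaves is a six-membered aromatic ring of carbon only carrying two fluorine atoms; the ring that enters has one hetero atom and no fluorine.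

Neither measured step touches this kind of change. The nearest is a 1.4-fold higher number from compound 1 to compound 2 (0.13 log units; within the scatter), which added a fluorine to the same ring and moved nothing beyond the scatter; the step of a 1.6-fold lower number from compound 2 to compound 3 (0.21 log units; within the scatter) changed a distant part of the molecule. Among the measured compounds shown here, no measured step speaks to replacing the whole ring. The expectation is therefore a step of a 1.0-fold higher number from compound 3 to compound 4 (0.01 log units; within the scatter), that is, none beyond the scatter, and compound 4 is estimated at 3000 nM, ranging from 1000 nM to 9000 nM.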

Compound 4, half-maximal inhibitory concentration: 9660 nM
Beside the measured number, compound 4's estimate is 3.2-fold (0.51 log units) below it; the measured number lies above the stated range.
By their numbers in this assay, from the lowest: compounds 3, 1 and 2 (each within the scatter of the next); then compound 4.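

Among the compounds shown here, this is the first step that lies beyond the scatter: in this assay the number rises, a 3.3-fold higher number from compound 3 to compound 4 (0.52 log units; beyond the scatter), which means weaker inhibition. For the compounds shown here, the earlier steps, one adding a fluorine to this same ring and one changing the distant group on the carbonyl carbon, stayed within the scatter, so this group on a nitrogen on an aromatic ring is the first place where a change shows a clear effect on the read-out. No measurement offered here accounts for the loss.

The exchange does two things at once, since the aromatic ring with one hetero atom and no fluorine arrives together with a methyl group on the carbon of the double bond, and the compounds shown cannot separate the share of each. They also leave open how a plain phenyl ring, or a ring carrying a methoxy group or an amine, would read out in this place with the dimethylamino chain kept as it is.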